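A few compounds are considered here, and "the series" means these few. Any claim that something is new, unique, unknown or untested is made for them only; others in the source may bear on it.

Among the measured compounds shown here, in a functional assay on PC-3 cells (Homo sapiens) for inhibition, read by sulforhodamine B assay, with a stated time of 48 h, tested at 50 uM (on this read-out lower numbers stand for less inhibition of growth and higher numbers for more inhibition of growth at the one concentration tested), compound 1 (`COc1cc2c(cc1CC=C(C)C)C(=O)C[C@@H](c1ccc(Oc3cccc([N+](=O)[O-])c3)cc1)O2`) gives 21% and stands lowest of the three numbers so far. Compound 2 (`COc1cc2c(cc1CC=C(C)C)/C(=N/O)C[C@@H](c1ccc(O)cc1)O2`) gives 81% and compound 3 (`COc1ccc([C@@H]2C/C(=N/OCc3cn(-c4ccc(C(N)=O)cc4)nn3)c3cc(CC=C(C)C)c(OC)cc3O2)cc1`) gives 100% as well, both beyond the scatter from compound 1, although neither differs from it in one place only. Compound 4 (`COc1cc2c(cc1CC=C(C)C)C(=O)C[C@@H](c1ccc(Oc3ccc(Br)cc3)cc1)O2`) has 4-bromophenyl in place of 3-nitrophenyl on an oxygen on an aromatic ring and otherwise keeps the core of compound 1. For the measured compounds named here, no measured pair tests this change, so no step beyond the scatter is expected in this assay and a small upward drift is the working guess. The estimated step is a number 7 percentage points higher from compound 1 to compound 4 (within the scatter) on that basis. Compound 4 is expected at 28% with an estimated range from 8% to 55% in this series.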

Compound 4, percent growth inhibition at one concentration: 55%
For compound 4 the middle estimate is 27 percentage points below the measured one, and the stated range covers the measured number.
By their numbers in this assay, from the lowest: compound 1; then compound 4; then compound 2; then compound 3.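

In this assay, 4-bromophenyl in place of 3-nitrophenyl on an oxygen on an aromatic ring gives a large step, a number 34 percentage points higher from compound 1 to compound 4 (beyond the scatter). Among the compounds shown here, this is the first single-place comparison, and it shows that the group on this oxygen alone can shift growth inhibition beyond the scatter while the core of compound 1 stays unchanged. No supporting measurement bears on the reason for this step.

Compound 4 lacks the nitro group and carries a bromine. The data do not separate these two differences. An unsubstituted phenyl or a 4-aminophenyl on the same oxygen would be needed to divide them.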